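Hydroxymethyl to 3-hydroxypropyl on the shared core

The compounds below may be only part of what the source reports. "The series", "measured", "known", "first", "only" and "open" are said of these compounds alone.

Compound 1, `O=c1oc(CO)cc2ccccc12`, gives only a limit in a functional assay on NCI/ADR-RES cells (Homo sapiens) for antiproliferative activity, read by sulforhodamine B assay, with a stated time of 48 h; on this read-out higher numbers stand for weaker inhibition of growth and lower numbers for stronger inhibition of growth: >= 250 ug/mL.
Compound 2, `COc1ccc2cc(CO)oc(=O)c2c1`, gives 160 ug/mL in this assay.

Compound 2 carries the only number shown; the other value is a limit. Compound 3, `COc1ccc2cc(CCCO)oc(=O)c2c1`, differs from compound 2 by 2-hydroxyethyl in place of hydroxy on a saturated chain carbon bound to an aromatic carbon. Among the measured compounds shown here, the sole measured step, an at least 1.5-fold lower number from compound 1 to compound 2 (0.19 log units; that floor lies within the scatter), concerns a methoxy on an aromatic carbon, not the chain, and is itself within the scatter, so it offers no guide to this change. No step beyond the scatter is therefore expected: no change at the digits printed from compound 2 to compound 3 (within the scatter). For compound 3 the expected value in this assay is 160 ug/mL, with a range of 70 ug/mL to 350 ug/mL.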

Compound 3, concentration for 50% growth inhibition: 28.1 ug/mL
Estimate against measurement, compound 3: 5.7-fold (0.76 log units) above, and the stated range ends above it.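

In this assay, among the compounds shown here, hydroxymethyl to 3-hydroxypropyl gives a 5.7-fold lower number from compound 2 to compound 3 (0.76 log units; beyond the scatter), the first step beyond the scatter. The saturated chain carbon bound to an aromatic carbon is thus a place where growth inhibition responds, and a single change there gives no trend with chain length. Compound 1 gives a limit and not a number: the limit of >= 250 ug/mL in this assay, at which 1 of the 3 values shown sits.

Still open, going by these compounds, is whether a longer chain continues this step, or whether an amine or a carboxylic acid in place of the terminal hydroxy keeps it. Also open, on these data alone, is whether 3-hydroxypropyl gives the same step on the core of compound 1, without the methoxy.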